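Hexyl ester in place of the phenylpropyl ester

The compounds below may be only part of what the source reports. "The series", "measured", "known", "first", "only" and "open" are said of these compounds alone.

Measured so far:
compound 1 `CCCOC(=O)c1ccc(CN)cc1` — 500000000 nM
compound 2 `NCc1ccc(C(=O)OCc2ccc(Cl)cc2)cc1` — 30000000 nM
compound 3 `NCc1ccc(C(=O)OCCCc2ccccc2)cc1` — 500000000 nM

In an assay on isolated protein for inhibition of serine protease 1 (Homo sapiens) (on this read-out higher numbers stand for weaker inhibition and lower numbers for stronger inhibition), compound 1 gives 500000000 nM, while compound 2 gives 30000000 nM and compound 3 gives 500000000 nM. Compound 3 stands level with compound 1 at the digits shown, and these two are together the highest numbers of the three; compound 2 is the furthest from compound 3, with a lower number that lies beyond the scatter. For the measured compounds named here, the one step that ends at compound 3 is no change at the digits printed from compound 1 to compound 3 (within the scatter), so adding the ring to the chain of compound 1 did nothing this assay could resolve.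

Compound 4 `CCCCCCOC(=O)c1ccc(CN)cc1` is the next case: propyl in place of phenyl on a saturated chain carbon, three bonds along the chain from an oxygen next to a carbonyl group. Going by the values given here, the step that bears on it is the one from compound 1 to compound 3, which showed no change, and compound 4 amounts to compound 1 carried on by the same chain without the ring. The step from compound 3 to compound 4 is therefore expected to be no change at the digits printed from compound 3 to compound 4 (within the scatter), none beyond the scatter. Compound 4 is accordingly estimated at 500000000 nM, with a range from 150000000 nM to 1500000000 nM.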

Compound 4, inhibition constant: 300000000 nM
Compound 4: the middle estimate sits 1.7-fold (0.22 log units) above what was measured; measured number inside the range.
By their numbers in this assay, from the lowest: compound 2; then compounds 4, 1 and 3 (each within the scatter of the next).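

In this assay, propyl at this saturated chain carbon gives a 1.7-fold lower number from compound 3 to compound 4 (0.22 log units; within the scatter), so the ring of compound 3 can be exchanged for a ring-free chain of fewer carbons without leaving the scatter. Against the hydrogen at the same place, the propyl gives a 1.7-fold lower number from compound 1 to compound 4 (0.22 log units; within the scatter), so a purely saturated extension also stays within the scatter, a result that the phenyl step alone could not show. Thus neither phenyl nor propyl at this place separates from hydrogen, and no independent evidence bears on this outcome.

Still open, going by these compounds, is whether any group at this place can move the number beyond the scatter. A longer chain, or a chain ending in an amine or a carboxylic acid, would be a further test of that.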